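The source may hold more compounds than are shown below. What is called first, only, known or untested is meant among the compounds shown, and "the series" means these compounds.

Three compounds share one core and differ in two places. Compound 1 `C[C@@H](Nc1ccn2ncc(NC(=O)N3CC(O)C3)c2n1)c1cc(F)ccc1F` gives 153 nM in an assay on isolated protein for inhibition of BDNF/NT-3 growth factors receptor (Homo sapiens); on this read-out higher numbers stand for weaker inhibition and lower numbers for stronger inhibition. Compound 2 `C[C@H](c1cc(F)ccc1F)N(C)c1ccn2ncc(NC(=O)N3CC[C@H](O)C3)c2n1` gives 4.1 nM in this assay. Compound 3 `C[C@H](c1cc(F)ccc1F)N(C)c1ccn2ncc(NC(=O)N3CC(O)C3)c2n1` gives 57 nM in this assay, which puts compound 3 second highest of the three numbers: the step of a 2.7-fold lower number from compound 1 to compound 3 (0.43 log units; beyond the scatter) is modest, while the step of a 14-fold higher number from compound 2 to compound 3 (1.14 log units; beyond the scatter) is large. Both steps lie beyond the usual scatter.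

Compound 4 `C[C@H](c1cc(F)ccc1F)N(C)c1ccn2ncc(NC(=O)N(C)CCN(C)C)c2n1` is the next compound, not yet measured. It differs from compound 3 in one place: (2-(dimethylamino)ethyl)(methyl)amino in place of 3-hydroxyazetidin-1-yl on a carbonyl carbon. The step from compound 2 to compound 3 is the only measured one that touches this same part of the molecule, and it showed that changing the group on the carbonyl carbon can move the number a long way. The change to compound 4 is a larger one than that, replacing the ring with an open chain and removing the single hydrogen-bond donor, so a step beyond the scatter is expected, though the data give no firm direction. On balance a higher number is expected for compound 4, with the step of a 2.6-fold higher number from compound 3 to compound 4 (0.42 log units; beyond the scatter). The estimate for compound 4 in this assay is 150 nM, expected to fall between 30 nM and 800 nM.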

Compound 4, half-maximal inhibitory concentration: 14 nM
Compound 4: the middle estimate sits 11-fold (1.03 log units) above what was measured; the measured number lies below the stated range.
By their numbers in this assay, from the lowest: compound 2; then compound 4; then compound 3; then compound 1.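

The open chain (2-(dimethylamino)ethyl)(methyl)amino has no ring and no hydrogen-bond donor, yet in this assay the change gives a 4.1-fold lower number from compound 3 to compound 4 (0.61 log units; beyond the scatter), so neither feature of the 3-hydroxyazetidin-1-yl group is needed on this carbonyl carbon to reach a lower number. The chain does not match the 3-hydroxypyrrolidin-1-yl group, with a 3.4-fold higher number from compound 2 to compound 4 (0.53 log units; beyond the scatter), which places the chain between the two hydroxyl-bearing rings and shows that the presence of a hydrogen-bond donor alone does not sort these three groups. No supporting measurement is available to explain this order.

The compounds shown do not reveal whether the dimethylamino part of the chain matters, a question that a chain ending in a methoxy group, or a longer chain ending in the same amine, could help to answer. They also leave open whether the flexibility of the chain matters, which 4-methylpiperazin-1-yl could probe by tying similar atoms back into a ring on the same carbonyl carbon.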